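Trifluoromethyl in place of fluoro: compound 3 to compound 4

The source may report more compounds than this note shows. Statements on the series, on what has been measured and on what is new or still open speak of the compounds shown alone.

Values in an ADME assay on Caco-2 cells (Homo sapiens) for cytotoxicity, read by neutral red uptake, with a stated time of 72 h; a lower number here means that less compound is tolerated, a higher number that more compound is tolerated:
- Compound 1 `COc1cc(NC(C)CCCNC(=O)C2CCC3(CC2)OOC2(OO3)C3CC4CC(C3)CC2C4)c2ncccc2c1-c1ccc(F)cc1`: > 50000 nM (a limit)
- Compound 2 `COc1cc(NC(C)CCCNC(=O)C2CCC3(CC2)OOC2(OO3)C3CC4CC(C3)CC2C4)c2ncccc2c1-c1ccc(Cl)cc1`: > 50000 nM (a limit)
- Compound 3 `COc1cc(NC(C)CCCNCC2CCC3(CC2)OOC2(OO3)C3CC4CC(C3)CC2C4)c2ncccc2c1-c1ccc(F)cc1`: "not determined" (no result reported)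

Compound 3 has no number to start from, since its result reads "not determined" (no result reported). For the measured compounds named here, the only values nearby are those of the limit of > 50000 nM in this assay, at which 2 of the 3 values shown sit.

Compound 4 `COc1cc(NC(C)CCCNCC2CCC3(CC2)OOC2(OO3)C3CC4CC(C3)CC2C4)c2ncccc2c1-c1ccc(C(F)(F)F)cc1` differs from compound 3 by trifluoromethyl in place of fluoro on an aromatic carbon.

Going by the values given here, the one measured step that changes the group on this aromatic carbon is a step that the two limits leave unreadable from compound 1 to compound 2, chloro in place of fluoro. It gives no size to carry over, so no size or direction of step can be expected in this assay for this change. The expectation therefore rests on compound 2, whose > 50000 nM is a limit. With no measured value for compound 3, the range is kept wide, and a report of only a limit remains quite possible.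

For compound 4 the expected value is 35000 nM, with an estimated range from 10000 nM to 100000 nM.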

Compound 4, half-maximal cytotoxic concentration: 10300 nM
Estimate against measurement, compound 4: 3.4-fold (0.53 log units) above; low and high end bracket the measured number.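

No step can be read from compound 3 to compound 4: in this assay compound 3 reads "not determined" (no result reported), so compound 4 with 10300 nM has no partner value. From the compounds shown here alone, what the change from 4-fluorophenyl to 4-(trifluoromethyl)phenyl does to tolerated concentration stays open.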